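The compounds below may be only part of what the source reports. "The series", "measured", "known", "first", "only" and "open" are said of these compounds alone.

Compound 2 `CC(C)(C)c1ccc(C(=O)N2CCC3(CC2)C(=O)N(CC(=O)N2CCCC(O)C2)CN3c2ccccc2)cc1` and compound 3 `CC(C)(C)c1ccc(C(=O)N2CCC3(CC2)C(=O)N(CC(=O)NCCCNS(C)(=O)=O)CN3c2ccccc2)cc1` share a core with compound 1 `COC(=O)CCNC(=O)CN1CN(c2ccccc2)C2(CCN(C(=O)c3ccc(C(C)(C)C)cc3)CC2)C1=O`. In an assay on HEK293 cells for displacement of a labelled ligand from NPC1-like intracellular cholesterol transporter 1 (Homo sapiens) (a higher number here means a weaker inhibitor, a lower number a stronger inhibitor), compound 1 gives "not determined" (no result reported). In this assay compound 2 gives 12200 nM, and compound 3 gives 10400 nM. The step of a 1.2-fold lower number from compound 2 to compound 3 (0.07 log units; within the scatter), produced by (3-(methanesulfonamido)propyl)amino in place of 3-hydroxypiperidin-1-yl on a carbonyl carbon, shows that this part of the molecule can be rebuilt without a change beyond the scatter. Compound 3 therefore stands at the lowest of the two numbers, with compound 2 close by and within the scatter, so neither can be called the stronger inhibitor.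

Compound 4 `CC(C)(C)OC(=O)NCCCNC(=O)CN1CN(c2ccccc2)C2(CCN(C(=O)c3ccc(C(C)(C)C)cc3)CC2)C1=O` is the next variation at the same end of the chain. It differs from compound 3 by tert-butoxycarbonyl in place of methylsulfonyl on an amine nitrogen. Among the measured compounds shown here, no measured step in this set exchanges these two groups, so the only guide is the step from compound 2 to compound 3, which was within the scatter, and it suggests that alterations in this region leave the number where it is. Compound 4 is thus expected to show a 1.0-fold lower number from compound 3 to compound 4 (0.02 log units; within the scatter), with no step beyond the scatter in either direction. The estimate for compound 4 in this assay is 10000 nM, with a range from 4000 nM to 25000 nM.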

Compound 4, half-maximal inhibitory concentration: 4500 nM
Compound 4: the middle estimate sits 2.2-fold (0.35 log units) above what was measured, and the stated range covers the measured number.
By their numbers in this assay, from the lowest: compound 4; then compounds 3 and 2 (each within the scatter of the next).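

Exchanging the group on the amine nitrogen of the chain in this assay gives a 2.3-fold lower number from compound 3 to compound 4 (0.36 log units; beyond the scatter) and so moves the number beyond the scatter, which a 1.2-fold lower number from compound 2 to compound 3 (0.07 log units; within the scatter) did not do. This position therefore responds to the group on that nitrogen, although the response is modest, and the earlier step had not revealed this. Against the 3-hydroxypiperidin-1-yl amide, the same result reads as a 2.7-fold lower number from compound 2 to compound 4 (0.43 log units; beyond the scatter), which makes compound 4 the strongest inhibitor of the three compounds with a number, as both of its steps lie beyond the scatter. Nothing measured here explains why tert-butoxycarbonyl gives a lower number than methylsulfonyl.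

The compounds shown leave open whether a free amine, an acetyl group or a benzyloxycarbonyl group on the same nitrogen would keep, extend or lose this modest gain. They also leave open how a shorter or longer chain carrying the tert-butoxycarbonyl group would compare, and whether any such change could bring the number far below the level of compound 4, since all of the numbers shown remain in a narrow band.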